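Amide swaps on a shared core

The source may hold more compounds than are shown below. What is called first, only, known or untested is meant among the compounds shown, and "the series" means these compounds.

compound 1 (`NC(=O)Cn1c(-c2ccc(Cl)cc2)nc2cccnc21`) gives 4.1 mg/kg
compound 2 (`CNC(=O)Cn1c(-c2ccc(Cl)cc2)nc2cccnc21`) gives 12.5 mg/kg
compound 3 (`CCN(CC)C(=O)Cn1c(-c2ccc(Cl)cc2)nc2cccnc21`) gives 16 mg/kg

In a functional assay on the whole organism with Mus musculus as the target (a lower number here means that less compound is needed, a higher number that more compound is needed for the effect), compound 3 sits level with compound 2 within the usual scatter, and compound 1 lies clearly lower. That gap is modest (a 3.9-fold higher number from compound 1 to compound 3 (0.59 log units; beyond the scatter)). Compound 4 (`CCCN(C)C(=O)Cn1c(-c2ccc(Cl)cc2)nc2cccnc21`) carries methyl(propyl)amino in place of diethylamino on a carbonyl carbon, so the same atoms are joined differently. The closest guide is the swap of methylamino for diethylamino, which stayed within the scatter (a 1.3-fold higher number from compound 2 to compound 3 (0.11 log units; within the scatter)). The larger step came with methyl in place of the amide hydrogen (a 3.0-fold higher number from compound 1 to compound 2 (0.48 log units; beyond the scatter)), a change not repeated here. No step beyond the scatter is therefore expected (a 1.1-fold lower number from compound 3 to compound 4 (0.03 log units; within the scatter)). Compound 4 is estimated at 15 mg/kg (range 7.5 mg/kg to 30 mg/kg).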

Compound 4, dose for half-maximal effect: 11.6 mg/kg
Beside the measured number, compound 4's estimate is 1.3-fold (0.11 log units) above it; the range from low to high includes it.
By their numbers in this assay, from the lowest: compound 1; then compounds 4, 2 and 3 (each within the scatter of the next).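

In this assay, rearranging the same atoms on the amide nitrogen, from diethylamino to methyl(propyl)amino, stays within the scatter (a 1.4-fold lower number from compound 3 to compound 4 (0.14 log units; within the scatter)), and so does propyl in place of hydrogen on the amide-type nitrogen (a 1.1-fold lower number from compound 2 to compound 4 (0.03 log units; within the scatter)). Compounds 2, 3 and 4 therefore sit level, so the exact alkyl groups matter little here, while the gap to the unsubstituted amide persists (a 2.8-fold higher number from compound 1 to compound 4 (0.45 log units; beyond the scatter)). No measured evidence explains this pattern.

Still open, on these data alone, is whether a ring on that nitrogen, such as a piperidine or morpholine amide, would stay level with these three compounds. A carboxylic acid in place of the amide could also land closer to compound 1.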